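Swapping nitro for methoxy on the acid of compound 2

The compounds below may be only part of what the source reports. "The series", "measured", "known", "first", "only" and "open" are said of these compounds alone.

Going by the values given here, compound 2 `O=C(O)C1=Cc2ccccc2OC1(OCc1cc(-c2ccc([N+](=O)[O-])cc2)no1)C(F)(F)F` is the one member of this small set with an actual number: in a functional assay on DU-145 cells (Homo sapiens) for inhibition, read by MTT assay, with a stated time of 24 h (a lower number here means a stronger inhibitor, a higher number a weaker inhibitor), compound 2 gives 100000 nM. The other two values are limits of the assay rather than numbers. Compound 1 `CCOC(=O)C1=Cc2ccccc2OC1(OCc1cc(-c2ccc(OC)cc2)no1)C(F)(F)F` sits at the limit > 150000 nM in this assay. Compound 3 `CCOC(=O)C1=Cc2ccccc2OC1(OCc1cc(-c2ccc([N+](=O)[O-])cc2)no1)C(F)(F)F` sits at the same limit, > 150000 nM, in this assay. Compound 2 therefore stands alone as the only measured potency, with both neighbours beyond the reach of the assay (the limit of > 150000 nM in this assay, at which 2 of the 3 values shown sit).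

Compound 4 `COc1ccc(-c2cc(COC3(C(F)(F)F)Oc4ccccc4C=C3C(=O)O)on2)cc1` has not been measured. It differs from compound 2 in one place (methoxy in place of nitro on an aromatic carbon).

Two measured steps exist. The step of an at least 1.5-fold higher number from compound 2 to compound 3 (0.17 log units; that floor lies within the scatter) concerns the ester, not the aromatic substituent, and its floor lies within the scatter. The step that the two limits leave unreadable from compound 1 to compound 3 is the same swap of nitro and methoxy, taken in the reverse direction on the ester series, but two limits leave its size unreadable. Among the compounds with values here, no measured step therefore gives a readable direction for the change from compound 2 to compound 4, and no step beyond the scatter is expected.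

Compound 4 is accordingly estimated at 110000 nM, between 50000 nM and 220000 nM, a step of a 1.1-fold higher number from compound 2 to compound 4 (0.04 log units; within the scatter) that is expected to lie within the scatter, with a real chance that only a limit is reported.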

Compound 4, half-maximal inhibitory concentration: 42000 nM
Compound 4: the middle estimate sits 2.6-fold (0.42 log units) above what was measured; the measured number lies below the stated range.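

On the acid core, the change from 4-nitrophenyl to 4-methoxyphenyl moves the result in this assay: a 2.4-fold lower number from compound 2 to compound 4 (0.38 log units; beyond the scatter). Going by these compounds alone, this is the first readable size for this change at this place on the aromatic ring, as the same swap between the two ethyl esters is left unreadable by their limits. With the 4-methoxyphenyl group held fixed, the ester and the acid also separate clearly, with an at least 3.5-fold lower number from compound 1 to compound 4 (0.55 log units; beyond the scatter), and this step is only a floor, as the value of compound 1, > 150000 nM, is a limit of the assay and not a number.

The size of the ester-to-acid change on each core stays unsettled, and so does whether that size depends on the group on the aromatic ring: the same change on two cores in this assay, an at least 1.5-fold higher number (0.17 log units; that floor lies within the scatter) from compound 2 to compound 3 and an at least 3.5-fold higher number (0.55 log units; beyond the scatter) from compound 4 to compound 1; the limit leaves it open whether they differ How an amine or a chlorine on that aromatic carbon would read, or an amide in place of the carboxylic acid, lies outside the compounds shown, and with only the nitro and methoxy groups to compare, no trend across substituents can be drawn from them.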